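This account rests on a few compounds, and the source may have more. Where it says the series, first, only, none or still open, it means among the compounds named here.

The set comprises three compounds built on the same core. Compound 1 `COc1ccc(C2=Cc3ccc(F)cc3C(CC(C)=O)N2c2ccc(C#N)cc2)cc1` was run in an ADME assay on TZM cells (Homo sapiens) for cytotoxicity, read by CellTiter-Glo, with a stated time of 48 h (a higher number here means that more compound is tolerated, a lower number that less compound is tolerated), where compound 1 gives "not determined" (no result reported), so no number stands against it. Among the compounds with values here, compound 2 `COc1ccc(C2=Cc3ccc([N+](=O)[O-])cc3C(CC(C)=O)N2c2ccc(F)cc2)cc1` carries a nitro group on the core and a fluorine on the aryl ring attached to the nitrogen; in this assay compound 2 gives 7700 nM, and since compound 1 brought no number, this is the only value shown, with nothing to place it above or below. Compound 3 `COc1ccc(C2=Cc3ccc([N+](=O)[O-])cc3C(CC(C)=O)N2c2ccc(O)cc2)cc1` has not yet been measured in this assay. It differs from compound 2 in one place only: hydroxy in place of fluoro on an aromatic carbon. Within the data shown here, no measured pair in the set shows what such an exchange does in this assay, so there is no step to lean on. The change is small in heavy atoms, and with nothing in the data pointing one way, a step no larger than the usual scatter is expected from compound 2 to compound 3, a 1.2-fold higher number from compound 2 to compound 3 (0.07 log units; within the scatter). Compound 3 is therefore estimated at 9000 nM in this assay, with a range from 3000 nM to 30000 nM.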

Compound 3, half-maximal cytotoxic concentration: 23500 nM
Compound 3: middle estimate off by 2.6-fold (0.42 log units), on the low side; measured number inside the range.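

With compound 2 and compound 3 the set gains its first readable step in this assay, which is a 3.1-fold higher number from compound 2 to compound 3 (0.48 log units; beyond the scatter) and is modest in size. The exchange of 4-fluorophenyl for 4-hydroxyphenyl shows that this place, on an aromatic carbon para to a large group, is not silent in this read-out: replacing one heavy atom, fluorine, with one heavy atom, oxygen, while a hydrogen-bond donor and a hydrogen-bond acceptor enter, moves the number beyond the usual scatter, towards more compound being tolerated. Nothing measured alongside these compounds bears on why the number moves.

The compounds shown leave open whether this step belongs to hydroxy in particular or would also appear with another group at the same place, such as an amine or a carboxylic acid. Within the data shown here, they also leave open whether the exchange would give a step of similar size with the nitro group on the core replaced, since compound 1 , the only compound without that nitro group, gives "not determined" (no result reported) and differs from compound 2 in more than one place.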